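The compounds below may be only part of what the source reports. "The series", "measured", "known", "first", "only" and "open" are said of these compounds alone.

Measured so far:
Compound 1, `CCOC(=O)[C@](C)(Cc1ccccc1)c1c(C)cnc2c(-c3ccc(C(F)(F)F)cc3)cnn12`, gives 11 nM in a functional assay on CHO cells for agonist activity at Glucose-dependent insulinotropic receptor (Mus musculus), read by HTRF and cAMP accumulation; on this read-out lower numbers stand for an effect already at smaller amounts and higher numbers for an effect only at larger amounts of compound.
Compound 2, `CCOC(=O)[C@](C)(Cc1ccccc1)c1ccnc2c(-c3ccc(C(F)(F)F)cc3)c(C)nn12`, gives 24 nM in this assay.

Of these two numbers, compound 1 holds the lower one. Compound 2 stands higher, and the gap between the two lies beyond the usual scatter of repeated measurements, so compound 1 is the more potent of the pair.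

Compound 3, `CCOC(=O)[C@](C)(Cc1ccccc1)c1c(Cl)cnc2c(-c3ccc(C(F)(F)F)cc3)cnn12`, has not yet been measured. It differs from compound 1 in one place only: chloro in place of methyl on an aromatic carbon. Among the compounds with values here, no measured pair in this set shows what such an exchange does, so there is no step to lean on. One heavy atom is swapped for another of similar size at the same position, and the expectation is a step of modest size at most, in no firm direction, quite possibly within the scatter. The step from compound 1 to compound 3 is expected to be a 1.1-fold higher number from compound 1 to compound 3 (0.04 log units; within the scatter). Compound 3 is therefore estimated at 12 nM, within a range from 5 nM to 30 nM.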

Compound 3, half-maximal effective concentration: 8 nM
The estimate for compound 3 lay 1.5-fold (0.18 log units) above the measured number; measured number inside the range.
By their numbers in this assay, from the lowest: compounds 3 and 1 (each within the scatter of the next); then compound 2.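

Exchanging methyl for chloro on this aromatic carbon, ortho to a large group, gives a 1.4-fold lower number from compound 1 to compound 3 (0.14 log units; within the scatter). In this assay, within the data shown here, the position therefore accepts a chlorine atom in place of a carbon-based group with no step beyond the scatter, something the earlier compounds could not show because no measured pair differed at this place alone. Nothing measured here gives a reason why the two groups read alike.

These two small groups say little about how much variety the position can carry, so a methoxy group, an amine, a nitrile or a longer chain at this carbon could read quite differently. Going by these compounds, it also remains open whether the bare ring carbon with only hydrogen would match compound 1 and compound 3.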